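This account rests on a few compounds, and the source may have more. Where it says the series, first, only, none or still open, it means among the compounds named here.

Measured compounds:
- Compound 1, `C=CCNC(=S)N/N=C/c1ccc(OCc2ccc3c(c2)=[N+]([O-])C(C)(C)[N+]=3[O-])cc1`, gives > 100 uM in an ADME assay on cells (Erythrocyte, Homo sapiens), read by spectrophotometry and hemolysis, with a stated time of 24 h; a lower number here means a stronger inhibitor, a higher number a weaker inhibitor; this value is a limit of this assay, not a number.
- Compound 2, `CC1(C)[N+]([O-])=c2ccc(COc3ccc(/C=N/NC(=S)Nc4ccccc4)cc3)cc2=[N+]1[O-]`, gives < 50 uM in this assay; this too is a limit, not a number.
- Compound 3, `C=CCNC(=S)N/N=C\c1ccccc1OCc1ccc2c(c1)=[N+]([O-])C(C)(C)[N+]=2[O-]`, gives "nd(insoluble)" (no result reported) in this assay, so no result is reported for it.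

Compound 1 and compound 2 differ in one place: phenyl in place of allyl on an amide-type nitrogen. This gives an at least 2.0-fold lower number from compound 1 to compound 2 (0.30 log units; that floor lies within the scatter), and the two ends of that step rest on limits, namely the limit of < 50 uM in this assay, at which 1 of the 3 values shown sits, and (the limit of > 100 uM in this assay, at which 1 of the 3 values shown sits), so its true size is not pinned down.

Compound 3 and compound 1 are built from the same atoms joined differently; the difference between the two cores is not broken down here.

Compound 4, `CC1(C)[N+]([O-])=c2ccc(COc3ccccc3/C=N\NC(=S)Nc3ccccc3)cc2=[N+]1[O-]`, has not yet been measured. It stands to compound 3 as compound 2 stands to compound 1: phenyl in place of allyl on an amide-type nitrogen, at the same place in both pairs, so the change is the same. Among the measured compounds shown here, compound 3 gave no result, so the step from it cannot be sized; the only guide is the step from compound 1 to compound 2, itself bounded by limits. Compound 4 is therefore expected to fall near 40 uM in this assay, within 15 uM to 150 uM, and a limit rather than a number is quite possible.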

Compound 4, concentration for 50% inhibition: 66 uM
For compound 4 the middle estimate is 1.7-fold (0.22 log units) below the measured one; the range from low to high includes it.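

Among the compounds shown here, compound 3 has no reported result, so no step from it to compound 4 can be read. Left open is how large the change from allyl to phenyl on an amide-type nitrogen truly is, and whether it is the same in both pairs, given that compound 1 and compound 2 rest on limits: the limit of < 50 uM in this assay, at which 1 of the 4 values shown sits.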